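Amide nitrogen methylation on the shared core series

The source may report more compounds than this note shows. Statements on the series, on what has been measured and on what is new or still open speak of the compounds shown alone.

Measured so far:
compound 1, `COc1ccc(-c2cc(NC(=O)CCC(=O)N(C)CC(=O)NC3CCCCC3)nc(-c3ccc(OC)cc3)n2)cc1`: in an assay on HeLa cells for displacement of a labelled ligand from adenosine receptor A3 (Homo sapiens), read by fluorescence polarization, with a stated time of 30 min (a higher number here means a weaker inhibitor, a lower number a stronger inhibitor), compound 1 gives 52900 nM
compound 2, `COc1ccc(-c2cc(NC(=O)COCC(=O)NCC(=O)NCc3ccccc3)nc(-c3ccc(OC)cc3)n2)cc1`: in this assay compound 2 gives 185000 nM

Among the compounds with values here, compound 2 stands at the higher of the two numbers; compound 1 sits lower, but it differs from compound 2 in more than one place, so the two values give no single step. Compound 3, `COc1ccc(-c2cc(NC(=O)COCC(=O)N(C)CC(=O)NCc3ccccc3)nc(-c3ccc(OC)cc3)n2)cc1`, differs from compound 2 by methyl in place of hydrogen on an amide-type nitrogen. Within the data shown here, no measured pair isolates this change. The expectation for compound 3 is therefore a modest step, more likely downward than upward and possibly inside the scatter, as a 1.7-fold lower number from compound 2 to compound 3 (0.23 log units; within the scatter). For compound 3 the estimate in this assay is 110000 nM, with a range from 40000 nM to 300000 nM.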

Compound 3, inhibition constant: 40100 nM
For compound 3 the middle estimate is 2.7-fold (0.44 log units) above the measured one; measured number inside the range.
By their numbers in this assay, from the lowest: compounds 3 and 1 (each within the scatter of the next); then compound 2.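

Methyl in place of hydrogen on the amide-type nitrogen is the first single change that can be read in this series: in this assay it gives a 4.6-fold lower number from compound 2 to compound 3 (0.66 log units; beyond the scatter) and no more than that one methyl differs. This nitrogen therefore responds to substitution, with the number moving beyond the scatter toward a stronger inhibitor. Nothing available explains the step.

From the compounds shown here alone, whether an ethyl group or a longer chain on this nitrogen would move the number further remains open. So does the effect of the same methyl on the other amide nitrogens of compound 2.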